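A few compounds are considered here, and "the series" means these few. Any claim that something is new, unique, unknown or untested is made for them only; others in the source may bear on it.

The series shares one core, seen in compound 1 `CN(C)c1c(C(=O)c2ccccc2)sc2nc(-c3cccs3)ccc12`, compound 2 `COc1ccc(C(=O)c2sc3nc(-c4cccs4)ccc3c2N)cc1` and compound 3 `COc1ccc(C(=O)c2sc3nc(-c4cccs4)ccc3c2N)c(OC)c1`. In a functional assay on WI-38 VA13 cells (Homo sapiens) for cytotoxicity (a higher number here means that more compound is needed for the effect, a lower number that less compound is needed), compound 1 gives only a limit, > 4 ug/mL, and no number (the limit of > 4 ug/mL in this assay, at which 1 of the 3 values shown sits). In this assay compound 2 gives 0.77 ug/mL, the higher of the two numbers that are known; in this assay compound 3 gives 0.52 ug/mL. For the measured compounds named here, the one measured step, a 1.5-fold lower number from compound 2 to compound 3 (0.17 log units; within the scatter), lies within the scatter, so the two numbers show no difference that can be read.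

Compound 4 `Nc1c(C(=O)c2cccc(F)c2)sc2nc(-c3cccs3)ccc12` is not yet measured. It differs from compound 2 in one place: 3-fluorophenyl in place of 4-methoxyphenyl on a carbonyl carbon. Going by the values given here, no measured step changes the ring on the carbonyl carbon in this way; the only step that touches that ring is a 1.5-fold lower number from compound 2 to compound 3 (0.17 log units; within the scatter), and it stayed within the scatter. On that basis no step beyond the scatter is expected in this assay in either direction. For compound 4 the expected value in this assay is 0.9 ug/mL, with a range from 0.3 ug/mL to 3 ug/mL. The expected step is a 1.2-fold higher number from compound 2 to compound 4 (0.07 log units; within the scatter), within the scatter.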

Compound 4, half-maximal effective concentration: 0.025 ug/mL
For compound 4 the middle estimate is 36-fold (1.56 log units) above the measured one, and the stated range ends above it.
By their numbers in this assay, from the lowest: compound 4; then compounds 3 and 2 (each within the scatter of the next). At a limit, above all of these: compound 1.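

For the compounds shown here, the ring on the carbonyl carbon is not a silent position in this assay: 3-fluorophenyl in place of 4-methoxyphenyl gives a 31-fold lower number from compound 2 to compound 4 (1.49 log units; beyond the scatter), whereas the only earlier change at this ring gave a 1.5-fold lower number from compound 2 to compound 3 (0.17 log units; within the scatter). This change replaces the group and also alters where the substituent is named on the ring, and the compounds shown do not separate these two parts of the step. Nothing among the measurements shown gives a cause for this step.

Going by these compounds, it remains open whether 4-fluorophenyl or 3-methoxyphenyl on the carbonyl carbon would give a number closer to that of compound 4 or that of compound 2. Also open, on these data alone, is whether 3-chlorophenyl, or a phenyl ring carrying an amine or a carboxylic acid, would keep the low number of compound 4.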